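Substituent swap on the aryl amide of the shared core

The source may report more compounds than this note shows. Statements on the series, on what has been measured and on what is new or still open speak of the compounds shown alone.

Measured so far in an ADME assay on PC-3 cells (Homo sapiens) for cytotoxicity, read by WST assay, tested at 100 uM; on this read-out lower numbers stand for less inhibition and higher numbers for more inhibition at the one concentration tested (going by the name of the read-out):
compound 1, `O=C(Nc1cccc(CN2CCCC2)c1)C1CCCN(C(=O)c2cc(C(F)(F)F)cc(C(F)(F)F)c2)C1`: 51%
compound 2, `COC(=O)c1cccc(NC(=O)C2CCCN(C(=O)c3cc(C(F)(F)F)cc(C(F)(F)F)c3)C2)c1`: 0%

Among the compounds with values here, compound 2 stands lowest of the two numbers; its nearest neighbour is compound 1, and the single measured step, a number 51 percentage points lower from compound 1 to compound 2 (beyond the scatter), is large. Compound 3, `O=C(Nc1cccc(S(=O)(=O)N2CCCC2)c1)C1CCCN(C(=O)c2cc(C(F)(F)F)cc(C(F)(F)F)c2)C1`, differs from compound 2 in one place: (pyrrolidin-1-yl)sulfonyl in place of methoxycarbonyl on an aromatic carbon. Within the data shown here, only that one step bears on this change, and it concerns a different exchange, so it gives weak guidance; a step from compound 2 that stays small or modest is expected. Compound 3 is estimated at 10%, within 0% to 35%, an expected step of a number 10 percentage points higher from compound 2 to compound 3 (within the scatter).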

Compound 3, a percentage reported as inhibition, at one concentration (the size of the read-out at that concentration, not a potency): 0%
Compound 3: middle estimate off by 10 percentage points, on the high side; low and high end bracket the measured number.
By their numbers in this assay, from the lowest: compounds 2 and 3 (each within the scatter of the next); then compound 1.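

In this assay, replacing methoxycarbonyl with the larger (pyrrolidin-1-yl)sulfonyl gives no change at the digits printed from compound 2 to compound 3 (within the scatter). The pyrrolidine ring alone therefore does not preserve the read-out at this aromatic carbon: with (pyrrolidin-1-yl)sulfonyl in place of (pyrrolidin-1-yl)methyl, the result is a number 51 percentage points lower from compound 1 to compound 3 (beyond the scatter). No available data explain either step.

On these data alone, it remains open whether the higher read-out extends to other amines on a methylene link, such as dimethylaminomethyl or piperidin-1-ylmethyl. A carboxylic acid at the same position is also an open case.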